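Methoxy at the phenol position of a KIF15 series

This account rests on a few compounds, and the source may have more. Where it says the series, first, only, none or still open, it means among the compounds named here.

Measured compounds, each with its result at one concentration:
- compound 1, `O=C1Nc2ccc(C(=O)c3ccco3)cc2/C1=C/c1cc(Br)c(O)c(Br)c1`: 65%
- compound 2, `O=C1Nc2ccc(C(=O)c3ccco3)cc2/C1=C/c1cc(F)c(O)c(Br)c1`: 38%
- compound 3, `O=C1Nc2ccc(C(=O)c3ccco3)cc2/C1=C/c1cc(Br)cc(Br)c1`: 16%

All three share one core and differ only in the substituents on the outer aromatic ring. In an assay on HeLa cells for inhibition of Kinesin-like protein KIF15 (Homo sapiens), read by microscopy, with stated times of 2 s and 20 s, tested at 750 nM (on this read-out lower numbers stand for less inhibition and higher numbers for more inhibition at the one concentration tested (going by the name of the read-out)), compound 1 gives 65%, the highest number here. Compound 2 gives 38%, and the change of fluoro in place of bromo on an aromatic carbon produces a number 27 percentage points lower from compound 1 to compound 2 (beyond the scatter). Compound 3 gives 16% and stands lowest of the three: compound 2 is nearest, and compound 1 furthest, so that a number 49 percentage points lower from compound 1 to compound 3 (beyond the scatter) and a number 22 percentage points lower from compound 2 to compound 3 (beyond the scatter).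

Compound 4, `COc1c(Br)cc(/C=C2\C(=O)Nc3ccc(C(=O)c4ccco4)cc32)cc1Br`, has not yet been measured. It differs from compound 3 by methoxy in place of hydrogen on an aromatic carbon. Among the compounds with values here, the step that bears most on this is the one from compound 1 to compound 3, where hydrogen in place of hydroxy gave a number 49 percentage points lower from compound 1 to compound 3 (beyond the scatter), a large drop. Within the data shown here, compound 4 restores an oxygen at that carbon, but as a methoxy rather than a hydroxy, and no measured pair shows whether methoxy behaves like hydroxy or like hydrogen here. A partial recovery is therefore expected: for compound 4 the estimate is a number 16 percentage points higher from compound 3 to compound 4 (beyond the scatter), so compound 4 is expected to give about 32%, within roughly 12% to 55%.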

Compound 4, a percentage reported as inhibition, at one concentration (the size of the read-out at that concentration, not a potency): -12.6%
Compound 4: the middle estimate sits 44.6 percentage points above what was measured, outside the stated range (below it).
By their numbers in this assay, from the lowest: compound 4; then compound 3; then compound 2; then compound 1.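

Putting an oxygen back at this carbon is not enough to recover the read-out: a methyl in place of the hydrogen on the phenol oxygen gives a number 77.6 percentage points lower from compound 1 to compound 4 (beyond the scatter) in this assay and removes all of the inhibition that compound 1 shows. Methoxy therefore does not behave as a weaker hydroxy, or even as a neutral swap for hydrogen, since adding it gives a number 28.6 percentage points lower from compound 3 to compound 4 (beyond the scatter) and leaves compound 4 with a negative reading. Among the three compounds with two bromo groups on the outer ring, the order at this carbon runs from hydroxy at the top, through hydrogen, to methoxy at the bottom, but nothing shown here explains that order.

Still open, from the compounds shown here alone, is whether other groups at this carbon, such as an amine, a carboxylic acid or a longer ether like ethoxy, would fall with methoxy or rise towards hydroxy. It is also unknown whether methoxy would have the same effect on the outer ring of compound 2, which carries a fluoro and a bromo group.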